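Swapping the thiophene for chlorophenyl on a thiazole

This account rests on a few compounds, and the source may have more. Where it says the series, first, only, none or still open, it means among the compounds named here.

Measured compounds:
- compound 1 `O=C(O)CC1COc2cc(OCc3nnc(-c4ccccc4)s3)ccc21`: 3.36%
- compound 2 `O=C(O)CC1COc2cc(OCc3ncc(-c4ccccc4)o3)ccc21`: 2.34%
- compound 3 `Cc1nc(-c2ccsc2)sc1COc1ccc2c(c1)OCC2CC(=O)O`: 56.5%

Three compounds share an acid-bearing core and differ in the aromatic piece attached through a methylene ether. In a functional assay on CHO cells for agonist activity at Free fatty acid receptor 1 (Homo sapiens), read by FLIPR and calcium flux, tested at 100 nM (a higher number here means a stronger effect of the compound at the concentration tested, a lower number a weaker effect), compound 1 gives 3.36%, and compound 2 gives 2.34%; both numbers are small. Compound 3 stands clearly apart: in this assay compound 3 gives 56.5%, the highest of the three, and its distance to both compound 1 and compound 2 lies beyond the usual scatter, so it counts as the most active of the set.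

Compound 4 `Cc1nc(-c2ccccc2Cl)sc1COc1ccc2c(c1)OCC2CC(=O)O` keeps the whole of compound 3 except for one change: 2-chlorophenyl in place of thiophen-3-yl on an aromatic carbon. Compound 1 and compound 2 carry a plain phenyl on a different ring and are weak, but no single-change comparison with compound 3 exists, so the size of the effect is open. The expectation is a moderate drop, with the step from compound 3 to compound 4 in this assay estimated at a number 14.5 percentage points lower from compound 3 to compound 4 (beyond the scatter). For compound 4 the expected value is 42%, estimated within 12% to 72%.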

Compound 4, a percentage reported as activity, at one concentration (the size of the read-out at that concentration, not a potency): 12.4%
The estimate for compound 4 lay 29.6 percentage points above the measured number, and the stated range covers the measured number.
By their numbers in this assay, from the lowest: compounds 2, 1 and 4 (each within the scatter of the next, the first and the last beyond it); then compound 3.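

Among the compounds shown here, this is the first comparison in the set that changes only one group, and it shows that the aromatic carbon of the five-membered aromatic ring with 1 nitrogen and 1 sulfur is sensitive to what it carries. In this assay, 2-chlorophenyl in place of thiophen-3-yl gives a number 44.1 percentage points lower from compound 3 to compound 4 (beyond the scatter) while the rest of the molecule stays fixed, so one aromatic ring cannot simply stand in for another at this place. Nothing available here explains the loss.

The exchange replaces the ring and adds a chlorine in the same step, so the compounds shown cannot say which of the two matters more. Plain phenyl at this same place, or a pyridine ring, would be needed to pull those two apart.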